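Pyridin-4-yl in place of 4-fluorophenyl: the next step

The source may hold more compounds than are shown below. What is called first, only, known or untested is meant among the compounds shown, and "the series" means these compounds.

Compound 1 `Cc1cc(NC(=O)Cn2cc(-c3cccc(Cl)c3)nn2)no1` returns only a limit in a functional assay on BMDM cells (Mus musculus, strain C57BL/6) for inhibition, with a stated time of 2 days (a lower number here means a stronger inhibitor, a higher number a weaker inhibitor), > 30000 nM. Compound 2 `Cc1cc(NC(=O)Cn2cc(-c3ccc(F)cc3)nn2)no1` likewise returns only a limit in this assay, > 30000 nM. The step that the two limits leave unreadable from compound 1 to compound 2 thus gives no size, and compound 2 stands at the limit of > 30000 nM in this assay, at which 2 of the 2 values shown sit, with no numeric value of its own. Compound 3 `Cc1cc(NC(=O)Cn2cc(-c3ccncc3)nn2)no1` differs by pyridin-4-yl in place of 4-fluorophenyl on an aromatic carbon. Going by the values given here, no measured step bears a readable size on this change. Compound 3 is expected to stay near the limit, an estimated step of a number no higher from compound 2 to compound 3 (the limit leaves the size open). The estimate for compound 3 is 30000 nM, with a range of 8000 nM to 120000 nM.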

Compound 3, half-maximal inhibitory concentration: 430 nM
The estimate for compound 3 lay 70-fold (1.84 log units) above the measured number, outside the stated range (below it).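

Pyridin-4-yl on this aromatic carbon gives an at least 69-fold lower number from compound 2 to compound 3 (1.84 log units; beyond the scatter) in this assay, and in place of 3-chlorophenyl it gives an at least 69-fold lower number from compound 1 to compound 3 (1.84 log units; beyond the scatter). The position therefore responds strongly to this change, which adds one hydrogen-bond acceptor in the ring; the step between the two substituted phenyl compounds cannot be read. Compound 1 and compound 2 each remain at a limit, not a number: the limit of > 30000 nM in this assay, at which 2 of the 3 values shown sit.

As far as these compounds go, whether the ring nitrogen or its placement carries the gain remains open. Pyridin-3-yl, pyridin-2-yl or unsubstituted phenyl at this carbon would test that.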